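From cyclopropyl to (4-methoxyphenyl)amino on a carbonyl carbon

This account rests on a few compounds, and the source may have more. Where it says the series, first, only, none or still open, it means among the compounds named here.

Compound 1 `COc1ccc(-n2c(SCc3ccc(C)cc3)nnc2-c2cc(OC)c(OC)c(OC)c2)cc1`: 33300 nM
Compound 2 `COc1ccc(-n2c(SCC(=O)C3CC3)nnc2-c2cc(OC)c(OC)c(OC)c2)cc1`: > 60000 nM (a limit, not a number)

Both compounds were tested in a functional assay on HCT-116 cells (Homo sapiens) for inhibition, read by MTT assay, with a stated time of 48 h; on this read-out higher numbers stand for weaker inhibition and lower numbers for stronger inhibition. Going by these compounds, compound 2 stands at the limit of > 60000 nM in this assay, at which 1 of the 2 values shown sits, so its exact place on the scale is unknown.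

Compound 3 `COc1ccc(NC(=O)CSc2nnc(-c3cc(OC)c(OC)c(OC)c3)n2-c2ccc(OC)cc2)cc1` differs from compound 2 at one place: (4-methoxyphenyl)amino in place of cyclopropyl on a carbonyl carbon. In plain words, (4-methoxyphenyl)amino takes the place of cyclopropyl on a carbonyl carbon. An aromatic ring thereby enters, and compound 1 also carries one, in its 4-methylphenyl group.

Within the data shown here, only one measured step bears on this change: an at least 1.8-fold higher number from compound 1 to compound 2 (0.25 log units; that floor lies within the scatter). It comes with cyclopropylcarbonyl in place of 4-methylphenyl on a saturated chain carbon bound to a sulfur. This is thin evidence and sets no firm size for the next step. Compound 3 may also stay at the limit of this assay. If it gives a number, a value in the region of compound 1, at 33300 nM, seems the most reasonable expectation. The expected change is an at least 2.0-fold lower number from compound 2 to compound 3 (0.30 log units; that floor lies within the scatter). For compound 3 the estimate is 30000 nM, with an expected range from 9000 nM to 60000 nM.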

Compound 3, half-maximal inhibitory concentration: > 60000 nM
Compound 3 ended at the assay's limit; the forecaster's own chance of this, stated with the estimate: 35%; middle value at least 2.0-fold (0.30 log units) away from the limit.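

An aromatic ring is not enough by itself: carried by (4-methoxyphenyl)amino on a carbonyl carbon, it still leaves compound 3 without a readable number in this assay, even though compound 1 also has an aromatic ring in its 4-methylphenyl group and does give one. Among these compounds, the only readable comparison is an at least 1.8-fold higher number from compound 1 to compound 3 (0.25 log units; that floor lies within the scatter), for (4-methoxyphenyl)carbamoyl in place of 4-methylphenyl on a saturated chain carbon bound to a sulfur, so this step alone does not establish a real loss of activity. The step from compound 2 to compound 3 cannot be read, since both values are limits rather than numbers: the limit of > 60000 nM in this assay, at which 2 of the 3 values shown sit.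

Going by these compounds, how far compound 2 and compound 3 each lie past that limit remains open, so the cyclopropyl and (4-methoxyphenyl)amino groups cannot be ranked against each other. Also open, on these data alone, is whether a smaller or differently built group on the same carbonyl carbon, such as a hydroxyl group, as in a carboxylic acid, or a dimethylamino group, would give a readable number in this assay.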